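Fluoro on the sulfonyl aryl of the trimethoxy anilino compound

A few compounds are considered here, and "the series" means these few. Any claim that something is new, unique, unknown or untested is made for them only; others in the source may bear on it.

Measured so far:
compound 1 `COc1cc(Nc2nc3ccccc3nc2S(=O)(=O)c2ccccc2)cc(OC)c1`, 70 nM
compound 2 `COc1cc(Nc2nc3ccccc3nc2S(=O)(=O)c2ccccc2)cc(OC)c1OC`, 9660 nM
compound 3 `COc1ccc(Nc2nc3ccccc3nc2S(=O)(=O)c2ccc(F)cc2)cc1`, 4840 nM

In a functional assay on A549 cells (Homo sapiens) for cytotoxicity, read by MTT assay, with a stated time of 72 h (a higher number here means a weaker inhibitor, a lower number a stronger inhibitor), compound 2 gives the highest of the three numbers; its nearest neighbour is compound 3, a gap within the scatter, and its furthest is compound 1, from which it is separated by a 140-fold higher number from compound 1 to compound 2 (2.14 log units; beyond the scatter). Compound 4 `COc1cc(Nc2nc3ccccc3nc2S(=O)(=O)c2ccc(F)cc2)cc(OC)c1OC` differs from compound 2 by one change: fluoro in place of hydrogen on an aromatic carbon. For the measured compounds named here, no measured step covers this change; the only measured step concerns a methoxy group on the anilino ring. Compound 3 carries the same fluoro group but differs from compound 2 in several places, so its value says little on its own. The expected step in this assay is therefore a 1.1-fold lower number from compound 2 to compound 4 (0.03 log units; within the scatter), none beyond the scatter. Compound 4 is estimated at 9000 nM, between 3000 nM and 30000 nM.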

Compound 4, half-maximal inhibitory concentration: > 50000 nM
Compound 4: a limit, no number; the forecaster's own chance of this, stated with the estimate: 5%; middle value at least 5.5-fold (0.74 log units) away from the limit.
By their numbers in this assay, from the lowest: compound 1; then compounds 3 and 2 (each within the scatter of the next). At a limit, above all of these: compound 4.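

For the compounds shown here, the phenylsulfonyl ring, which no earlier single step touched, responds to one added atom: in this assay, 4-fluorophenyl in place of phenyl gives an at least 5.1-fold higher number from compound 2 to compound 4 (0.71 log units; beyond the scatter). This ring is therefore not a neutral place on the trimethoxy anilino compound. Compound 4 stands at a limit of the assay and not at a number, so the full size of this step stays unknown: the limit of > 50000 nM in this assay, at which 1 of the 4 values shown sits.

On these data alone, whether fluoro has the same effect on compound 1, without the extra methoxy, stays open. As far as these compounds go, how an amine or a carboxylic acid at this place would read also stays open.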